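Swapping the aromatic group on compound 3

The source may report more compounds than this note shows. Statements on the series, on what has been measured and on what is new or still open speak of the compounds shown alone.

In a functional assay on MCF7 cells (Homo sapiens) for antiproliferative activity, read by MTT assay, with a stated time of 72 h (on this read-out lower numbers stand for stronger inhibition and higher numbers for weaker inhibition), compound 3 `CC1=CC[C@H]2[C@H](CC[C@]2(C)O)C(C)(C)[C@@H]1CC[C@H]1[C@]2(C)CC[C@H](OC(=O)c3ccc(C(F)(F)F)cc3)C(C)(C)O[C@H]2CC[C@@]1(C)O` gives 23400 nM, the only actual number among those shown. Compound 1 `CC1=CC[C@H]2[C@H](CC[C@]2(C)O)C(C)(C)[C@@H]1CC[C@H]1[C@]2(C)CC[C@H](OC(=O)CCC(=O)O)C(C)(C)O[C@H]2CC[C@@]1(C)O` gives > 50000 nM, which is a limit. Compound 2 `CC1=CC[C@H]2[C@H](CC[C@]2(C)O)C(C)(C)[C@@H]1CC[C@H]1[C@]2(C)CC[C@H](OC(=O)NS(=O)(=O)c3ccc(C)cc3)C(C)(C)O[C@H]2CC[C@@]1(C)O` gives > 50000 nM, also a limit. Within the data shown here, two measured steps bear on the next change: an at least 2.1-fold lower number from compound 1 to compound 3 (0.32 log units; beyond the scatter) and an at least 2.1-fold lower number from compound 2 to compound 3 (0.32 log units; beyond the scatter). Each installs 4-(trifluoromethyl)phenyl on a carbonyl carbon. Compound 4 `CC1=CC[C@H]2[C@H](CC[C@]2(C)O)C(C)(C)[C@@H]1CC[C@H]1[C@]2(C)CC[C@H](OC(=O)c3cccc([N+](=O)[O-])c3)C(C)(C)O[C@H]2CC[C@@]1(C)O` carries 3-nitrophenyl in its place (3-nitrophenyl in place of 4-(trifluoromethyl)phenyl on a carbonyl carbon), keeping one six-membered aromatic ring of carbon only. Among the measured compounds shown here, no measured step exchanges one such ring for another, and no change beyond the scatter is expected. The expected outcome is a 1.2-fold higher number from compound 3 to compound 4 (0.08 log units; within the scatter). For compound 4 the estimated value is 28000 nM, with an expected range of 11000 nM to 50000 nM.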

Compound 4, half-maximal inhibitory concentration: 36000 nM
The estimate for compound 4 lay 1.3-fold (0.11 log units) below the measured number; measured number inside the range.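

In this assay, the exchange on the carbonyl carbon gives a 1.5-fold higher number from compound 3 to compound 4 (0.19 log units; within the scatter), so 3-nitrophenyl and 4-(trifluoromethyl)phenyl cannot be told apart at this position. The comparisons with the other two compounds read an at least 1.3-fold lower number from compound 1 to compound 4 (0.14 log units; that floor lies within the scatter) and an at least 1.3-fold lower number from compound 2 to compound 4 (0.14 log units; that floor lies within the scatter), and these floors alone do not set compound 4 apart from compound 1 or compound 2. Both floors rest on the same assay limit: the limit of > 50000 nM in this assay, at which 2 of the 4 values shown sit.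

From the compounds shown here alone, it remains open how an amine or a carboxylic acid on the aromatic ring would read. The compounds shown also do not separate the effect of the group's identity from that of its place on the ring.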